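The compounds below may be only part of what the source reports. "The series", "measured", "known", "first", "only" and "open" are said of these compounds alone.

In a functional assay on K562 cells (Homo sapiens) for cytotoxicity, read by trypan blue exclusion, with a stated time of 96 h (a lower number here means a stronger inhibitor, a higher number a weaker inhibitor), compound 1 `COc1cc(OC)c(/C=C/S(=O)(=O)Cc2ccc(Cl)c(N)c2)c(OC)c1` gives 10 nM and compound 2 `COc1cc(OC)c(/C=C/S(=O)(=O)Cc2ccc(F)c([N+](=O)[O-])c2)c(OC)c1` gives 25000 nM while compound 3 `COC(=O)CNc1cc(CS(=O)(=O)/C=C/c2c(OC)cc(OC)cc2OC)ccc1OC` gives 100 nM in the same test series. Compound 3 thus holds the second highest of the three numbers, far nearer to compound 1 than to compound 2. Compound 4 `COC(=O)C(Nc1cc(CS(=O)(=O)/C=C/c2c(OC)cc(OC)cc2OC)ccc1OC)c1ccccc1` departs from compound 3 by one change, (phenyl in place of hydrogen on a saturated chain carbon bound to a carbonyl carbon and a nitrogen on an aromatic ring), which places phenyl on a saturated chain carbon bound to a carbonyl carbon and a nitrogen on an aromatic ring. Within the data shown here, no measured pair isolates this change, so the expectation is tentative. A modest weakening in this assay is expected, with the estimated step of a 2.5-fold higher number from compound 3 to compound 4 (0.40 log units; beyond the scatter) as its size. In this assay the estimated value for compound 4 is 250 nM with an expected range from 40 nM to 2000 nM for now.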

Compound 4, half-maximal inhibitory concentration: 30 nM
The estimate for compound 4 lay 8.3-fold (0.92 log units) above the measured number, and the stated range ends above it.
By their numbers in this assay, from the lowest: compound 1; then compound 4; then compound 3; then compound 2.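

The step shows that this saturated chain carbon, bound to a carbonyl carbon and a nitrogen on an aromatic ring, can carry more than hydrogen: in this assay, phenyl gives a 3.3-fold lower number from compound 3 to compound 4 (0.52 log units; beyond the scatter), a modest gain rather than a loss. Nothing available explains why the phenyl group has this effect. The compounds shown leave open whether a methyl or isopropyl group on this carbon would also lower the number, or whether the phenyl ring itself is needed. They also leave open how a carboxylic acid in place of the methyl ester would behave.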